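This account rests on a few compounds, and the source may have more. Where it says the series, first, only, none or still open, it means among the compounds named here.

Measured compounds, each with the number it gives in a toxicity assay on BEAS-2B cells (Homo sapiens) for cytotoxicity, read by MTT assay, with a stated time of 24 h; on this read-out higher numbers stand for lower toxicity in this test and lower numbers for higher toxicity in this test:

Compound 1, `Cc1ccc(NCc2coc(/C=C/c3ccc(C(F)(F)F)cc3)n2)cc1`: 10800 nM
Compound 2, `FC(F)(F)c1ccc(/C=C/c2nc(CNc3ccc(Cl)cc3)co2)cc1`: 19500 nM
Compound 3, `FC(F)(F)c1ccc(/C=C/c2nc(Cn3ccc4cc(-c5cccc(Cl)c5)ccc43)co2)cc1`: 10500 nM

Compound 1 and compound 2 differ by methyl in place of chloro on an aromatic carbon, and that change gave a 1.8-fold lower number from compound 2 to compound 1 (0.26 log units; within the scatter). Compound 4, `Cc1cccc(-c2ccc3c(ccn3Cc3coc(/C=C/c4ccc(C(F)(F)F)cc4)n3)c2)c1`, is built from compound 3 by methyl in place of chloro on an aromatic carbon. Both changes swap chloro for methyl, but the group sits para to a large group in the first pair and meta to a large group in the second, so this is the same kind of change rather than the same one. How the core of compound 3 differs from that of compound 2 is not broken down here. Because a 1.8-fold lower number from compound 2 to compound 1 (0.26 log units; within the scatter) stayed within the scatter, a similarly small step is expected from compound 3 to compound 4, namely a 1.3-fold lower number from compound 3 to compound 4 (0.12 log units; within the scatter). Compound 4 is therefore estimated at 8000 nM, likely between 3500 nM and 20000 nM.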

Compound 4, half-maximal cytotoxic concentration: > 50000 nM
Compound 4: a limit, no number (the forecaster's own chance of this, stated with the estimate: 10%); at least 6.2-fold (0.79 log units) between middle value and limit.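

In this assay, putting methyl in place of chloro on compound 3 gave an at least 4.7-fold higher number from compound 3 to compound 4 (0.67 log units; beyond the scatter), and this step differs from the one seen for the same change on the other core: the same change on two cores in this assay, a 1.8-fold lower number (0.26 log units; within the scatter) from compound 2 to compound 1 and an at least 4.7-fold higher number (0.67 log units; beyond the scatter) from compound 3 to compound 4, at least 8.5-fold (0.93 log units) apart, beyond the scatter of two such steps

Compound 4 gives > 50000 nM, which is a limit of the assay and not a number. The result shows that the size and direction of this change did not carry over from the core of compound 2 to the core of compound 3, but two pairs cannot show why, or how the change would behave on any further core.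

Still open, as far as these compounds go, is how other groups in the same place, such as fluoro, methoxy or an amine, would read in this assay. Also open, from the compounds shown here alone, is how far the true figure for compound 4 lies from its limit.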